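From an Acyl Amide to a Urea on the Shared Core

The compounds below may be only part of what the source reports. "The series", "measured", "known", "first", "only" and "open" are said of these compounds alone.

Compound 1, `O=C1NCCc2nc(C#Cc3ccccc3F)sc21`: > 10000 nM
Compound 2, `Fc1cccc(C#Cc2nc3c(s2)CN(C2CCOC2)CC3)c1`: 400 nM
Compound 3, `COC1CC(C(=O)N2CCc3nc(C#Cc4ccccc4)sc3C2)C1`: > 10000 nM

These three compounds share a core and were measured in an assay on HEK293 cells for negative allosteric modulation of metabotropic glutamate receptor 5 (Homo sapiens), read by FLIPR, with a stated time of 1 h; on this read-out lower numbers stand for stronger inhibition and higher numbers for weaker inhibition. Compound 2 gives 400 nM. For compound 1 the reading is a limit, > 10000 nM, not a number. For compound 3 the reading is likewise a limit, > 10000 nM, rather than a number. So compound 3 stands at the weak end of what has been seen here, sitting at the limit of > 10000 nM in this assay, at which 2 of the 3 values shown sit, together with compound 1, while compound 2 alone gives a measured number.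

Compound 4, `O=C(N1CCCC1)N1CCc2nc(C#Cc3ccccc3)sc2C1`, is not yet measured. It differs from compound 3 in one place: pyrrolidin-1-yl in place of 3-methoxycyclobutyl on a carbonyl carbon. The carbonyl carbon and the amide-type nitrogen in a ring stay; only the group on the carbonyl changes. Within the data shown here, no measured pair in this set isolates such a change, so there is little to go on. Among the measured compounds shown here, compound 2, the only compound with a number, contains no carbonyl, whereas compound 1 and compound 3 both contain one and both end at the limit. On that basis compound 4 is expected to stay close to compound 3, with the step of an at least 1.6-fold lower number from compound 3 to compound 4 (0.22 log units; that floor lies within the scatter) expected to be small or none beyond the scatter. The estimate for compound 4 in this assay is 6000 nM, within 1000 nM to 40000 nM, with a fair chance that only a limit is reported again.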

Compound 4, half-maximal inhibitory concentration: > 10000 nM
Compound 4: only a limit was reported; the forecaster's own chance of this, stated with the estimate: 45%; at least 1.6-fold (0.22 log units) between middle value and limit.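

In this assay compound 4 gives > 10000 nM as a limit, not a number. Compound 3 also ends at a limit, so no step can be read between compound 3 and compound 4. The compounds shown leave open whether any group on the carbonyl carbon of the shared core can give a measured number.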